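The source may report more compounds than this note shows. Statements on the series, on what has been measured and on what is new or still open speak of the compounds shown alone.

The measured compounds:

Compound 1, `COc1cc(/C=C/C(=O)OCCCO[N+](=O)[O-])ccc1OCCCO[N+](=O)[O-]`. In a functional assay on H266 cells (Homo sapiens) for cytotoxicity, read by resazurin assay, with a stated time of 72 h (a lower number here means a stronger inhibitor, a higher number a weaker inhibitor), compound 1 reaches only a limit of the assay, > 50000 nM, and not a number.
Compound 2, `O=C(/C=C/c1ccc(O)c(O)c1)OCc1c(-c2ccccc2)no[n+]1[O-]`. In this assay compound 2 gives 14200 nM.
Compound 3, `COc1cc(/C=C/C(=O)OCc2c(-c3ccccc3)no[n+]2[O-])ccc1O`. In this assay compound 3 gives 13400 nM.

Among the measured compounds shown here, compound 2 and compound 3 share one core, and the single change between them is hydrogen in place of methyl on an oxygen on an aromatic ring. That change produced a 1.1-fold higher number from compound 3 to compound 2 (0.03 log units; within the scatter), so the two values cannot be told apart. Compound 1 carries a different core; the difference between the two cores is not broken down here. Where compound 1 stands is known only as a limit: the limit of > 50000 nM in this assay, at which 1 of the 3 values shown sits.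

Compound 4, `O=C(/C=C/c1ccc(OCCCO[N+](=O)[O-])c(O)c1)OCCCO[N+](=O)[O-]`, has not yet been measured. For the measured compounds named here, it is obtained from compound 1 by hydrogen in place of methyl on an oxygen on an aromatic ring, which is the same change as the one from compound 3 to compound 2, made at a place described in the same words. Going by the values given here, the one measured example of this change moved the number hardly at all, and the starting point for compound 4 is itself only a limit. Compound 4 is therefore expected to stay around the limit, with an estimated value of 60000 nM and a likely range from 25000 nM to 150000 nM. This expectation rests on the step of a 1.1-fold higher number from compound 3 to compound 2 (0.03 log units; within the scatter) and on compound 1 sitting at the limit of > 50000 nM in this assay, at which 1 of the 3 values shown sits. The step that this estimate implies is a step that the limit leaves unreadable from compound 1 to compound 4, and it is expected to be small.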

Compound 4, half-maximal inhibitory concentration: > 50000 nM
Compound 4: a limit, no number; the forecaster's own chance of this, stated with the estimate: 70%; the middle value lies beyond the limit too.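

No new step can be read from compound 1 to compound 4 in this assay, because each of these two compounds gives only the same limit of the assay and not a number: the limit of > 50000 nM in this assay, at which 2 of the 4 values shown sit.

The compounds shown leave open what the change from methoxy to hydroxy does on the core of compound 1, and what actual number either compound would give.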